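The source may hold more compounds than are shown below. What is called first, only, known or untested is meant among the compounds shown, and "the series" means these compounds.

Measured so far:
- compound 1 `CCCCCN(CCCCC)C(=O)N1CCN(C(=O)N(c2ccccc2)c2ccccc2)[C@H](C(=O)N(C)CCN(C)C)C1`: 930 nM
- compound 2 `CCCCCN(CCCCC)C(=O)N1CCN(C(=O)N(c2ccccc2)c2ccccc2)[C@H](C(=O)N(C)CCN(C)Cc2cc(C)cc(C)c2)C1`: 200 nM

The two measured compounds share one core and differ only at the saturated chain carbon bound to the amine nitrogen. In an assay on CHO cells for binding affinity to Substance-P receptor (Homo sapiens) (a higher number here means a weaker inhibitor, a lower number a stronger inhibitor), compound 2 gives 200 nM, the lowest of the two numbers. In this assay compound 1 gives 930 nM. Going by the values given here, the single measured step is a 4.7-fold lower number from compound 1 to compound 2 (0.67 log units; beyond the scatter), which places compound 2 clearly ahead of compound 1.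

Compound 3 `CCCCCN(CCCCC)C(=O)N1CCN(C(=O)N(c2ccccc2)c2ccccc2)[C@H](C(=O)N(C)CCN(C)Cc2ccccc2OC)C1` carries 2-methoxyphenyl in place of 3,5-dimethylphenyl on a saturated chain carbon bound to an amine nitrogen. Among the compounds with values here, no measured pair compares one aromatic substituent against another at this position, so the only step that bears on the change is the one from compound 1 to compound 2, and it shows merely that putting an aromatic group on this carbon lowered the number by a modest amount. Whether a 2-methoxyphenyl group holds that gain is not settled by the data. The expected outcome is a small step toward a higher number, near the scatter, namely a 1.8-fold higher number from compound 2 to compound 3 (0.24 log units; within the scatter). Compound 3 is therefore estimated at 350 nM, with a range from 120 nM to 1000 nM.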

Compound 3, half-maximal inhibitory concentration: 17 nM
Compound 3: middle estimate off by 21-fold (1.31 log units), on the high side; measured number outside the range, below it.
By their numbers in this assay, from the lowest: compound 3; then compound 2; then compound 1.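

In this assay, the change from 3,5-dimethylphenyl to 2-methoxyphenyl on the saturated chain carbon bound to an amine nitrogen gives a 12-fold lower number from compound 2 to compound 3 (1.07 log units; beyond the scatter), so at this position the outcome depends on which aromatic group is present, not merely on the presence of one. Measured against hydrogen at the same carbon, 2-methoxyphenyl gives a 55-fold lower number from compound 1 to compound 3 (1.74 log units; beyond the scatter), a larger step than a 4.7-fold lower number from compound 1 to compound 2 (0.67 log units; beyond the scatter) obtained with 3,5-dimethylphenyl. No accompanying measurement bears on the origin of this difference between the two aromatic groups.

The two aromatic groups differ at once in their substituents and in where those substituents stand, so the compounds shown do not separate the gain from entry of the methoxy group, from loss of the two methyl groups, or from the change in substitution pattern. An unsubstituted phenyl on this carbon would give the missing reference point for both compounds, and a 2-ethoxyphenyl or 2-hydroxyphenyl group would show how far the oxygen-bearing substituent itself can be varied.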